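A few compounds are considered here, and "the series" means these few. Any claim that something is new, unique, unknown or untested is made for them only; others in the source may bear on it.

Of the compounds shown here, three built on one shared core have been tested in a functional assay on A549 cells (Homo sapiens) for cytotoxicity, read by MTT assay, with a stated time of 72 h; on this read-out lower numbers stand for an effect already at smaller amounts and higher numbers for an effect only at larger amounts of compound. Compound 1 has the structure `CCc1cccc2c(OC)c(-c3occ(C)c3CO)ccc12`; in this assay compound 1 gives 9.6 ug/mL. Compound 2, `CCOc1c(-c2occ(C)c2CO)ccc2c(CC)cccc12`, differs from compound 1 by methyl in place of hydrogen on a saturated chain carbon bound to an oxygen on an aromatic ring. For compound 2 this assay reports only a limit, > 10 ug/mL. That single change made the step of an at least 1.0-fold higher number from compound 1 to compound 2 (0.01 log units; that floor lies within the scatter). Compound 3, `CCc1cccc2c(OC)c(-c3occ(C)c3COC)ccc12`, differs from compound 1 in its core by methyl in place of hydrogen on an oxygen on a saturated carbon, and the step from that change reads an at least 1.0-fold higher number from compound 1 to compound 3 (0.01 log units; that floor lies within the scatter). For compound 3 too, this assay reports only a limit, > 10 ug/mL. Both of these limits sit at the limit of > 10 ug/mL in this assay, at which 2 of the 3 values shown sit. Compound 4, `CCOc1c(-c2occ(C)c2COC)ccc2c(CC)cccc12`, has not yet been measured; it stands to compound 3 as compound 2 stands to compound 1, through (methyl in place of hydrogen on a saturated chain carbon bound to an oxygen on an aromatic ring), the same change at the same place. Compound 3 already sits at a limit, and the earlier step of an at least 1.0-fold higher number from compound 1 to compound 2 (0.01 log units; that floor lies within the scatter) also ended at a limit. On that footing the step is expected to read a step that the limit leaves unreadable from compound 3 to compound 4. Compound 4 is thus expected to give about 15 ug/mL, most likely again as a limit, with a range from 7 ug/mL to 50 ug/mL.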

Compound 4, concentration for half-maximal effect: > 10 ug/mL
Compound 4 gave a limit, no number (the forecaster's own chance of this, stated with the estimate: 85%); the middle value lies beyond the limit too.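

Neither step into compound 4, from compound 2 or from compound 3, can be read, because all three compounds carry only a limit and no number: the limit of > 10 ug/mL in this assay, at which 3 of the 4 values shown sit. The compounds shown leave open what actual numbers compound 2, compound 3 and compound 4 would give in this assay and so whether either change shifts cytotoxicity at all.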